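Cytotoxicity notes on the shared core: a phenyl amide

A few compounds are considered here, and "the series" means these few. Any claim that something is new, unique, unknown or untested is made for them only; others in the source may bear on it.

Compound 1 `CN(C)c1cc2[nH]c(C3CCCCC3)nc2cc1NC(=O)c1cccs1` was tested in an ADME assay on Vero cells (Chlorocebus sabaeus) for cytotoxicity, read by resazurin assay, with a stated time of 3 days; on this read-out higher numbers stand for weaker inhibition and lower numbers for stronger inhibition. In this assay compound 1 gives > 100 ug/mL, which is a limit of the assay and not a number. Compound 2 `CCCN(CCC)c1cc2[nH]c(C3CCCCC3)nc2cc1NC(=O)c1ccccc1` gives > 100 ug/mL, again a limit. Compound 3 `O=C(CCc1ccccc1)Nc1cc2nc(C3CCCCC3)[nH]c2cc1N1CCCC1` gives > 100 ug/mL, also a limit. Going by the values given here, all three values shown sit at the limit of > 100 ug/mL in this assay, at which 3 of the 3 values shown sit, so no step between measured compounds can be drawn from them. Compound 4 `CN(C)c1cc2[nH]c(C3CCCCC3)nc2cc1NC(=O)c1ccc(C(C)(C)C)cc1` has not yet been measured; it differs from compound 1 by 4-(tert-butyl)phenyl in place of thiophen-2-yl on a carbonyl carbon. With every measured member of the series at the limit, the numbers give no direction. The expected step is a number no higher from compound 1 to compound 4 (the limit leaves the size open), none beyond the scatter. For compound 4 the expected value is 100 ug/mL, within 50 ug/mL to 200 ug/mL.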

Compound 4, half-maximal inhibitory concentration: > 100 ug/mL
Compound 4 was reported as a limit (the forecaster's own chance of this, stated with the estimate: 70%); the middle value lies on the limit itself.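

In this assay compound 4 gives > 100 ug/mL as a limit of the assay and not a number. No step from compound 1 to compound 4 can be read: the limit of > 100 ug/mL in this assay, at which 4 of the 4 values shown sit.

Open remains whether the group on the carbonyl carbon affects cytotoxicity at all, as none of the four compounds has a value short of the limit.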